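This account rests on a few compounds, and the source may have more. Where it says the series, first, only, none or still open, it means among the compounds named here.

Compound 3 `O=C1/C(=C/c2ccc(Cl)cc2)CN(C(=O)CCSCCS(=O)(=O)O)C/C1=C\c1ccc(Cl)cc1` and compound 1 `O=C1/C(=C/c2ccc(Cl)cc2)CN(C(=O)CCSCCO)C/C1=C\c1ccc(Cl)cc1` are built on the same core and differ in one place only. In a functional assay on HL-60 cells (Homo sapiens) for cytotoxicity, read by trypan blue exclusion, with a stated time of 48 h (a lower number here means that less compound is tolerated, a higher number that more compound is tolerated), compound 3 gives 29700 nM, whereas compound 1 gives 660 nM. The change between them is hydroxy in place of sulfo on a saturated chain carbon, two bonds along the chain from a sulfur, and it produced a 45-fold lower number from compound 3 to compound 1 (1.65 log units; beyond the scatter).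

Compound 2 `COc1ccc(/C=C2\CN(C(=O)CCSCCS(=O)(=O)O)C/C(=C\c3ccc(OC)cc3)C2=O)cc1` carries the same (2-sulfoethyl)sulfanyl chain on a second core; the difference between the two cores is not broken down here. In this assay compound 2 gives 91700 nM, the highest of the three numbers, and even its nearest neighbour, compound 3, lies beyond the scatter from it.

Compound 4 `COc1ccc(/C=C2\CN(C(=O)CCSCCO)C/C(=C\c3ccc(OC)cc3)C2=O)cc1` has not yet been measured in this assay. It stands to compound 2 as compound 1 stands to compound 3, through (hydroxy in place of sulfo on a saturated chain carbon, two bonds along the chain from a sulfur). The change occurs twice among the compounds shown, and the place is worded identically in both pairs, so it is the same change.

The expectation for compound 4 rests on a single observed step. Because a 45-fold lower number from compound 3 to compound 1 (1.65 log units; beyond the scatter) was large, a step of comparable size is expected from compound 2 to compound 4, namely a 46-fold lower number from compound 2 to compound 4 (1.66 log units; beyond the scatter). From the compounds shown here alone, whether the second core carries the change equally is unknown, so the range is kept wide. Compound 4 is therefore estimated at 2000 nM in this assay, expected to fall between 500 nM and 9000 nM.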

Compound 4, half-maximal cytotoxic concentration: 2670 nM
Beside the measured number, compound 4's estimate is 1.3-fold (0.13 log units) below it; low and high end bracket the measured number.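

In this assay, putting hydroxy in place of sulfo on the core of compound 2 gave a 34-fold lower number from compound 2 to compound 4 (1.54 log units; beyond the scatter), so the large step seen on the core of compound 1 appears again on a second core. Set side by side, the two steps agree in size: the same change on two cores in this assay, a 45-fold lower number (1.65 log units; beyond the scatter) from compound 3 to compound 1 and a 34-fold lower number (1.54 log units; beyond the scatter) from compound 2 to compound 4, 1.3-fold (0.12 log units) apart, within the scatter of two such steps. This shows that the change carried over from one core to the other in this series with its size intact, but it rests on two pairs only and says nothing about any further core, nor about why the number falls in either case.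

The compounds shown leave open whether a carboxylic acid or an amine in place of the sulfo group would give a number closer to that of the sulfo compounds or to that of the hydroxy compounds, and whether a longer chain in place of 2-hydroxyethyl would keep the step at this size. They also leave open how far the difference between the two cores acts on its own, since that difference is not broken down here.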